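The source may report more compounds than this note shows. Statements on the series, on what has been measured and on what is new or still open speak of the compounds shown alone.

Going by the values given here, compound 2 `Fc1ccc(Oc2cncc(C3=CC4CNCC(C3)C4)c2)cc1` gives 0.6 nM in an in vitro assay on SH-EP1 cells for displacement of a labelled ligand from Neuronal acetylcholine receptor; alpha4/beta2 (Homo sapiens) (a higher number here means a weaker inhibitor, a lower number a stronger inhibitor), the lower of the two numbers measured so far, although compound 1 `C1=C(c2cncc(OCc3ccccc3)c2)CC2CNCC1C2` at 0.7 nM sits within the scatter of it. Among the compounds with values here, the one measured step, a 1.2-fold lower number from compound 1 to compound 2 (0.07 log units; within the scatter), exchanged the group on the same oxygen and stayed within the scatter. Compound 3 `COc1cccc(Oc2cncc(C3=CC4CNCC(C3)C4)c2)c1` carries 3-methoxyphenyl in place of 4-fluorophenyl on an oxygen on an aromatic ring. That single step bears on this change only loosely, and no shift beyond the scatter is expected. For compound 3 the estimated value in this assay is 0.8 nM, with a range from 0.3 nM to 2.5 nM. The expected step is a 1.3-fold higher number from compound 2 to compound 3 (0.12 log units; within the scatter).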

Compound 3, inhibition constant: 0.9 nM
Compound 3: middle estimate off by 1.1-fold (0.05 log units), on the low side; the measured number falls inside the stated range.
By their numbers in this assay, from the lowest: compounds 2, 1 and 3 (each within the scatter of the next).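

With 3-methoxyphenyl on this oxygen, the number in this assay stays within the scatter of both earlier compounds (a 1.5-fold higher number from compound 2 to compound 3 (0.18 log units; within the scatter); a 1.3-fold higher number from compound 1 to compound 3 (0.11 log units; within the scatter)), so the three groups cannot be ranked. This change also brings in a hydrogen-bond acceptor, which 4-fluorophenyl lacks, and the step still does not leave the scatter. No measurement shown here explains this result. Still open, as far as these compounds go, is whether the number would hold with an amine or a carboxylic acid on the phenyl ring, or with a longer chain on this oxygen.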